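A few compounds are considered here, and "the series" means these few. Any claim that something is new, unique, unknown or untested is made for them only; others in the source may bear on it.

Of the compounds shown here, three that share one core have been tested in an assay on CHO cells for displacement of a labelled ligand from 5-hydroxytryptamine receptor 1D (Homo sapiens); a lower number here means a stronger inhibitor, a higher number a weaker inhibitor. Compound 1 `C[C@@H](NCC1CCN(CCCc2c[nH]c3ccc(-n4cnnc4)cc23)CC1)c1ccccc1` gives 1.4 nM, the lowest of the three numbers. Compound 2 `c1ccc(C2CCCCN2C2CCN(CCCc3c[nH]c4ccc(-n5cnnc5)cc34)CC2)cc1` gives 1.9 nM, which lies within the scatter of compound 1, while compound 3 `CN(Cc1cccs1)C1CCN(CCCc2c[nH]c3ccc(-n4cnnc4)cc23)CC1` gives 4.3 nM. Within the data shown here, the only single-place step among them, a 3.1-fold higher number from compound 1 to compound 3 (0.49 log units; beyond the scatter), shows that swapping the group on the saturated ring carbon can shift the number beyond the scatter. Compound 4 `O[C@@H]1Cc2ccccc2[C@H]1NC1CCN(CCCc2c[nH]c3ccc(-n4cnnc4)cc23)CC1` differs from compound 1 at the same place: (2-hydroxy-2,3-dihydro-1H-inden-1-yl)amino in place of ((1-phenylethyl)amino)methyl on a saturated ring carbon. Since a change at that position has so far weakened binding, a similar modest weakening is expected here, namely a 2.5-fold higher number from compound 1 to compound 4 (0.40 log units; beyond the scatter). Compound 4 is therefore expected to give about 3.5 nM in this assay, most likely between 1.2 nM and 10 nM.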

Compound 4, half-maximal inhibitory concentration: 6.6 nM
Beside the measured number, compound 4's estimate is 1.9-fold (0.28 log units) below it, and the stated range covers the measured number.
By their numbers in this assay, from the lowest: compounds 1 and 2 (each within the scatter of the next); then compounds 3 and 4 (each within the scatter of the next).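

A second replacement on this saturated ring carbon, (2-hydroxy-2,3-dihydro-1H-inden-1-yl)amino, gives a 4.7-fold higher number from compound 1 to compound 4 (0.67 log units; beyond the scatter), so both groups placed here in exchange for ((1-phenylethyl)amino)methyl raise the number. The two replacements themselves stay close, with a 1.5-fold higher number from compound 3 to compound 4 (0.19 log units; within the scatter), although their ring systems differ. No supporting evidence is available to explain these shifts. The compounds shown leave open whether the hydroxyl of compound 4 contributes to its number, and how a smaller group on this carbon, such as a plain amine or a carboxylic acid, would read.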